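A few compounds are considered here, and "the series" means these few. Any claim that something is new, unique, unknown or untested is made for them only; others in the source may bear on it.

Measured compounds:
compound 1, `Cc1cn2c(N3CC[C@H](N(C)C)C3)c(-c3ccccc3)c(C)c(C#N)c2n1`: 356 ug/mL
compound 2, `Cc1c(-c2ccccc2)c(N2CC[C@H](N(C)C)C2)n2nc(C(C)(C)COCc3ccccc3)nc2c1C#N`: < 3 ug/mL

Of the compounds shown here, two have been measured in a physicochemical assay for solubility, at pH 6.8; a higher number here means a more soluble compound, a lower number a less soluble compound. Compound 1, `Cc1cn2c(N3CC[C@H](N(C)C)C3)c(-c3ccccc3)c(C)c(C#N)c2n1`, gives 356 ug/mL in this assay. Compound 2, `Cc1c(-c2ccccc2)c(N2CC[C@H](N(C)C)C2)n2nc(C(C)(C)COCc3ccccc3)nc2c1C#N`, returns only a limit in this assay, namely < 3 ug/mL. Compound 2 thus stands at the limit of < 3 ug/mL in this assay, at which 1 of the 2 values shown sits, so no number is known for it, and the distance between compound 1 and compound 2 can only be said to be large, with compound 1 the more soluble of the pair.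

Compound 3, `CCCCc1nc2c(C#N)c(C)c(-c3ccccc3)c(N3CC[C@H](N(C)C)C3)n2n1`, has not yet been measured. It differs from compound 2 by butyl in place of 1-((benzyloxy)methyl)-1-methylethyl on an aromatic carbon. For the measured compounds named here, no step between two measured compounds covers this change, so the expectation rests on the two measured values alone. The account expects an upward step in this assay, beyond the usual scatter, amounting to an at least 10-fold higher number from compound 2 to compound 3 (1.00 log units; beyond the scatter). Compound 3 is accordingly estimated at 30 ug/mL, within a range from 5 ug/mL to 150 ug/mL.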

Compound 3, solubility: 33 ug/mL
Estimate against measurement, compound 3: 1.1-fold (0.04 log units) below; measured number inside the range.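

In this assay, the place on an aromatic carbon of the five-membered aromatic ring with 3 nitrogen turns out to be one where a single change moves the read-out well beyond the scatter: butyl in place of 1-((benzyloxy)methyl)-1-methylethyl gives an at least 11-fold higher number from compound 2 to compound 3 (1.04 log units; beyond the scatter). The two earlier compounds differ in more than one place, so this is the first step shown that can be tied to one position of the series. Compound 2 stands at a limit and not at a number, so the size of this step has a floor and no known top: the limit of < 3 ug/mL in this assay, at which 1 of the 3 values shown sits.

This one step changes several things at once, and it leaves open whether the six-membered aromatic ring, the ether oxygen or the branched carbon chain accounts for the difference. It also leaves open how the read-out would respond at this place to a shorter chain such as ethyl, to a benzyl group without the ether oxygen, or to a butyl chain ending in an amine.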